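Amide nitrogen substituent and Sgk1 inhibition in the sulfonamide series

This account rests on a few compounds, and the source may have more. Where it says the series, first, only, none or still open, it means among the compounds named here.

Compound 3 `CC(C)NC(=O)c1cc(-c2ccc(NS(=O)(=O)c3cccc(Cl)c3Cl)cc2)nc2[nH]ncc12` carries an isopropyl group on the amide nitrogen of the shared core and gives 17600 nM in an assay for inhibition of serine/threonine-protein kinase Sgk1 (Homo sapiens), with stated times of 30 min and 60 min, in the presence of a further agent that is not named here (a lower number here means a stronger inhibitor, a higher number a weaker inhibitor), the highest number among the values shown. Compound 1 `CC(C)N1CC[C@H](NC(=O)c2cc(-c3ccc(NS(=O)(=O)c4cccc(Cl)c4Cl)cc3)nc3[nH]ncc23)C1` gives 38 nM in this assay. For compound 2 `CCNC(=O)c1cc(-c2ccc(NS(=O)(=O)c3cccc(Cl)c3Cl)cc2)nc2[nH]ncc12` this assay reports only a limit, < 1920 nM. The step of a 460-fold higher number from compound 1 to compound 3 (2.67 log units; beyond the scatter) is large and in the direction of weaker inhibition; the step of an at least 9.1-fold higher number from compound 2 to compound 3 (0.96 log units; beyond the scatter) runs the same way. Compound 4 `CN1CCC(CNC(=O)c2cc(-c3ccc(NS(=O)(=O)c4cccc(Cl)c4Cl)cc3)nc3[nH]ncc23)C1` differs from compound 3 by (1-methylpyrrolidin-3-yl)methyl in place of isopropyl on an amide-type nitrogen, which re-introduces a five-membered ring with one nitrogen onto the amide nitrogen, as in compound 1 though linked through a methylene and with methyl rather than isopropyl on the ring nitrogen. The step of a 460-fold higher number from compound 1 to compound 3 (2.67 log units; beyond the scatter) bears most directly on this change and argues for a large move back towards lower numbers; the step of an at least 9.1-fold higher number from compound 2 to compound 3 (0.96 log units; beyond the scatter) supports the direction. Compound 4 is therefore expected to show a step of a 150-fold lower number from compound 3 to compound 4 (2.17 log units; beyond the scatter). The estimate for compound 4 in this assay is 120 nM, with a range from 25 nM to 600 nM.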

Compound 4, half-maximal inhibitory concentration: 45 nM
The estimate for compound 4 lay 2.7-fold (0.43 log units) above the measured number; the range from low to high includes it.
By their numbers in this assay, from the lowest: compounds 1 and 4 (each within the scatter of the next); then compound 3.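

Notes on the amide nitrogen substituent: on the amide-type nitrogen, (1-methylpyrrolidin-3-yl)methyl in place of isopropyl restores strong inhibition in this assay (a 390-fold lower number from compound 3 to compound 4 (2.59 log units; beyond the scatter)). Compound 4 is not separated from compound 1 (a 1.2-fold higher number from compound 1 to compound 4 (0.07 log units; within the scatter)), so in this pair a low number holds with the ring set one methylene further out and with methyl rather than isopropyl on the ring nitrogen. The steps to compound 4 and from compound 1 that involve compound 2 cannot be read because compound 2 is reported only as a limit: the limit of < 1920 nM in this assay, at which 1 of the 4 values shown sits.

From the compounds shown here alone, the methylene link and the ring nitrogen substituent change together here, so their separate contributions stay open. Whether the ring nitrogen itself is needed also stays open, since the compounds shown include neither a cyclopentylmethyl group nor an open-chain amine such as 2-(dimethylamino)ethyl.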